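The source may hold more compounds than are shown below. What is called first, only, known or untested is meant among the compounds shown, and "the series" means these compounds.

Three compounds have been measured in a physicochemical assay for solubility, at pH 7.4; on this read-out higher numbers stand for higher solubility and lower numbers for lower solubility:

- compound 1 `C[C@H]1[C@@H](N)CN1c1cc2c(cc1F)c(=O)c(C(=O)O)cn2C1CC1`: 6.1 ug/mL
- compound 2 `CN[C@H]1CN(c2cc3c(cc2F)c(=O)c(C(=O)O)cn3C2CC2)[C@@H]1C`: 9.2 ug/mL
- compound 3 `C[C@H]1[C@@H](N)CN1c1c(F)cc2c(=O)c(C(=O)O)cn(C3CC3)c2c1F`: 23.6 ug/mL

Compound 2 differs from compound 1 only in one place, (a group of 7 heavy atoms (5 carbon, 2 nitrogen; one four-membered non-aromatic ring with 1 hetero atom) in place of a group of 6 heavy atoms (4 carbon, 2 nitrogen; one four-membered non-aromatic ring with 1 hetero atom), on an aromatic carbon). In this assay this brought a 1.5-fold higher number from compound 1 to compound 2 (0.18 log units; within the scatter), so the two numbers cannot be told apart. Compound 3 differs from compound 1 in a different way, (fluoro in place of hydrogen on an aromatic carbon), and this gave a 3.9-fold higher number from compound 1 to compound 3 (0.59 log units; beyond the scatter). Compound 3 therefore carries the highest number of the three, its steps to compound 1 and compound 2 both lying beyond the scatter.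

Compound 4 `CN[C@H]1CN(c2c(F)cc3c(=O)c(C(=O)O)cn(C4CC4)c3c2F)[C@@H]1C` has not yet been measured. It differs from compound 3 by a group of 7 heavy atoms (5 carbon, 2 nitrogen; one four-membered non-aromatic ring with 1 hetero atom) in place of a group of 6 heavy atoms (4 carbon, 2 nitrogen; one four-membered non-aromatic ring with 1 hetero atom), on an aromatic carbon. This is the same kind of change as that from compound 1 to compound 2, though the place is not identical: here the aromatic carbon is ortho to two fluoro groups, whereas in compound 1 it is ortho to a single fluoro group.

On the basis of the earlier step, a 1.5-fold higher number from compound 1 to compound 2 (0.18 log units; within the scatter), compound 4 is expected to move by about a 1.3-fold higher number from compound 3 to compound 4 (0.10 log units; within the scatter) from compound 3, a step that would stay within the scatter. Compound 4 is thus estimated at 30 ug/mL in this assay, with a likely range from 12 ug/mL to 75 ug/mL.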

Compound 4, solubility: 13.1 ug/mL
Compound 4: middle estimate off by 2.3-fold (0.36 log units), on the high side; low and high end bracket the measured number.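

In this assay the larger four-membered-ring group in place of the smaller one gave (a 1.8-fold lower number from compound 3 to compound 4 (0.26 log units; within the scatter)) on the fluoro-bearing core and (a 1.5-fold higher number from compound 1 to compound 2 (0.18 log units; within the scatter)) on the core of compound 1, so in neither pair can the two numbers be told apart, and the opposite printed directions show no real reversal between the cores. The added fluoro likewise gave (a 1.4-fold higher number from compound 2 to compound 4 (0.15 log units; within the scatter)), whereas the same change gave (a 3.9-fold higher number from compound 1 to compound 3 (0.59 log units; beyond the scatter)) with the smaller group, though two pairs cannot show whether the swap truly behaves differently on the two cores or is simply small on both. Nothing on hand bears on why these numbers fall as they do.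

The compounds shown leave open how this read-out would respond to a longer chain on the amine, such as an ethyl group, where a larger step might be seen. They also leave open whether chloro in place of the added fluoro would give the same picture on either amine.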